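Swapping the carboxymethyl end of compound 2 for a piperidine amide

The compounds below may be only part of what the source reports. "The series", "measured", "known", "first", "only" and "open" are said of these compounds alone.

In an ADME assay on microsomes from liver (Mus musculus) for metabolic stability, read by LC-MS, using NADPH, with a stated time of 60 min, tested at 1 uM (a lower number here means that the compound disappears faster, a higher number that the compound lasts longer), compound 1 `O=S(=O)(c1cccc(C(F)(F)F)c1)n1ccc2ccc(-c3cc(F)cc(OC(F)F)c3)cc21` gives 0.652 h and compound 2 `O=C(O)CCC1Cc2ccc(-c3cc(F)cc(OC(F)F)c3)cc2N1S(=O)(=O)c1cccc(C(F)(F)F)c1` gives 1.02 h as its half-life, two numbers within the usual scatter of each other. Compound 3 `O=C(O)CCC1CN(S(=O)(=O)c2cccc(C(F)(F)F)c2)c2cc(-c3cc(F)cc(OC(F)F)c3)ccc21` reads 0.408 h as its half-life, which lies beyond the scatter from the number for compound 2. Compound 2 therefore cannot be told apart from compound 1, while its half-life is clearly longer than that of compound 3.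

Compound 4 `O=C(O)C1CCN(C(=O)CC2Cc3ccc(-c4cc(F)cc(OC(F)F)c4)cc3N2S(=O)(=O)c2cccc(C(F)(F)F)c2)CC1` shares its core with compound 2 and differs in one place, where the change reads (4-carboxypiperidin-1-yl)carbonyl in place of carboxymethyl on a saturated chain carbon bound to a saturated ring carbon and puts (4-carboxypiperidin-1-yl)carbonyl in place of carboxymethyl on a saturated chain carbon bound to a saturated ring carbon. Within the data shown here, no measured pair shows this change, so its size cannot be read from the data. The expectation starts from compound 2 at 1.02 h as the measured half-life and foresees no shift beyond the scatter in this assay for the new group. The step expected is a 1.1-fold lower number from compound 2 to compound 4 (0.05 log units; within the scatter) and it stays within the scatter. For compound 4 the estimated half-life is 0.9 h with an expected range from 0.4 h to 2 h in this measurement.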

Compound 4, half-life: 0.502 h
Compound 4: the middle estimate sits 1.8-fold (0.25 log units) above what was measured, within the range that was stated.
By their numbers in this assay, from the lowest: compounds 3, 4, 1 and 2 (each within the scatter of the next, the first and the last beyond it).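

Among these compounds, this is the first step that changes one place alone, and it shows that the position on a saturated chain carbon bound to a saturated ring carbon is not indifferent to the group it carries: in this assay, putting (4-carboxypiperidin-1-yl)carbonyl in place of carboxymethyl gives a 2.0-fold lower number from compound 2 to compound 4 (0.31 log units; beyond the scatter). The step is beyond the scatter, so the longer half-life of compound 2 does not survive this enlargement, even though the entering group keeps a carboxylic acid and adds a six-membered non-aromatic ring and a second double bond outside aromatic rings. No measurement at hand accounts for the shorter half-life of compound 4.

Among the compounds shown here, the single step changes the ring, the amide carbonyl and the distance to the carboxylic acid together, so it cannot show which of these goes with the shift. As far as these compounds go, an unsubstituted piperidin-1-ylcarbonyl group, a dimethylaminocarbonyl group or a longer chain ending in a carboxylic acid at this place would be needed to pull these apart, and whether the same change behaves alike on the core of compound 3 also stays open.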